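The source may report more compounds than this note shows. Statements on the series, on what has been measured and on what is new or still open speak of the compounds shown alone.

- Compound 1 `COc1cc2[nH]c(C)c(C3CCCCC3)c(=O)c2cc1Cl`: > 32700 nM, which is a limit of the assay and not a number
- Compound 2 `COc1cc2[nH]c(C)c(C)c(=O)c2cc1Cl`: 12200 nM

Going by the values given here, both results come from an ADME assay on J774 cells (Mus musculus) for cytotoxicity (a lower number here means that less compound is needed, a higher number that more compound is needed for the effect), and compound 2 holds the only true number so far. Compound 3 `COc1cc2[nH]c(C)c(C(C)C)c(=O)c2cc1Cl` carries isopropyl in place of methyl on an aromatic carbon. Among the compounds with values here, the one measured step that bears on this change is an at least 2.6-fold lower number from compound 1 to compound 2 (0.42 log units; beyond the scatter), with methyl in place of cyclohexyl. Going from methyl to isopropyl moves in the reverse direction, so a small rise is expected in this assay, perhaps no larger than the scatter. The expected change is a 1.7-fold higher number from compound 2 to compound 3 (0.24 log units; within the scatter). For compound 3 the estimated value is 21000 nM, within an expected range of 10000 nM to 38000 nM.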

Compound 3, half-maximal effective concentration: 21700 nM
For compound 3 the middle estimate is 1.0-fold (0.01 log units) below the measured one; the measured number falls inside the stated range.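

In this assay, swapping methyl for isopropyl at this position gives a 1.8-fold higher number from compound 2 to compound 3 (0.25 log units; within the scatter), so the two groups cannot be told apart here. Isopropyl against cyclohexyl gives an at least 1.5-fold lower number from compound 1 to compound 3 (0.17 log units; that floor lies within the scatter), so the clear step seen between cyclohexyl and methyl does not reappear as a clear step with isopropyl. That comparison has only a floor, as the value of compound 1 is a limit of the assay and not a number: the limit of > 32700 nM in this assay, at which 1 of the 3 values shown sits.

Still open, as far as these compounds go, is how an amine or a carboxylic acid at this position would read in this assay.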